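The source may hold more compounds than are shown below. What is called first, only, known or untested is meant among the compounds shown, and "the series" means these compounds.

Compound 1 `Nc1nc2ccccn2c1-c1ccc(O)cc1` and compound 2 `Cc1ccn2c(-c3ccc(O)cc3)c(N)nc2c1` share one core, carrying an amino group and a hydroxyphenyl group. In an assay on isolated protein for inhibition of ubiquitin carboxyl-terminal hydrolase 14 (Homo sapiens) (on this read-out higher numbers stand for weaker inhibition and lower numbers for stronger inhibition), compound 1 gives > 100000 nM, which is a limit of the assay and not a number. In this assay compound 2 gives > 100000 nM, again a limit and not a number. For the measured compounds named here, the single step between the two, a step that the two limits leave unreadable from compound 1 to compound 2, cannot be read in size, since the limit of > 100000 nM in this assay, at which 2 of the 2 values shown sit, holds both values. Compound 2 thus stands only at that limit, with no measured number to set it apart from compound 1.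

Compound 3 `Nc1nc2cc(C3CCNCC3)ccn2c1-c1ccc(O)cc1` differs from compound 2 by piperidin-4-yl in place of methyl on an aromatic carbon. Going by the values given here, no measured step speaks to this change: the only step available, the one from compound 1 to compound 2, is unreadable, and nothing shows whether a change at this position moves the read-out at all. The expectation for compound 3 can rest on no more than the limit of compound 2, so compound 3 is estimated at 60000 nM, within a range from 8000 nM to 300000 nM. The step expected from compound 2 to compound 3 is an at least 1.6-fold lower number from compound 2 to compound 3 (0.22 log units; that floor lies within the scatter), with a real chance that compound 3 again returns only a limit.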

Compound 3, half-maximal inhibitory concentration: > 100000 nM
Compound 3 gave a limit, no number; the forecaster's own chance of this, stated with the estimate: 60%; middle value at least 1.6-fold (0.22 log units) from the limit.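

In this assay compound 3 gives > 100000 nM as a limit of the assay and not a number. For the compounds shown here, no step from compound 1 or compound 2 to compound 3 can be read in size, since all three compounds sit together: the limit of > 100000 nM in this assay, at which 3 of the 3 values shown sit. The compounds shown leave open whether methyl or piperidin-4-yl at this position changes the inhibition at all.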